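A few compounds are considered here, and "the series" means these few. Any claim that something is new, unique, unknown or untested is made for them only; others in the source may bear on it.

Measured compounds:

Compound 1, `COc1ccc(-c2cc(/C=C/C(=O)c3ccc(N)cc3)[nH]n2)cc1`, gives 67%.
Compound 2, `COc1ccc(-c2cc(/C=C/C(=O)c3ccc(N)cc3)[nH]n2)cc1OC`, gives 87%.
Compound 3, `COc1cc(C(=O)/C=C/c2cc(-c3cc(OC)c(OC)c(OC)c3)n[nH]2)cc(OC)c1OC`, gives 70%.

All three were tested in a functional assay on HCT-116 cells (Homo sapiens) for cytotoxicity, read by sulforhodamine B assay, with a stated time of 48 h, tested at 1 uM; on this read-out lower numbers stand for a stronger effect and higher numbers for a weaker effect at the one concentration tested. Compound 1 and compound 2 share a core and differ in one place: hydrogen in place of methoxy on an aromatic carbon. That change made the step of a number 20 percentage points lower from compound 2 to compound 1 (beyond the scatter), which is beyond the scatter. Compound 3 is built on a different core; how its core differs from that of compound 2 is not broken down here. In this assay compound 3 gives 70%, which lies within the scatter of the value of compound 1, while the value of compound 2 stands beyond the scatter above it.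

Compound 4, `COc1ccc(-c2cc(/C=C/C(=O)c3cc(OC)c(OC)c(OC)c3)[nH]n2)cc1OC`, has not yet been measured. It is derived from compound 3 by hydrogen in place of methoxy on an aromatic carbon. Within the data shown here, this is the same kind of change as the one from compound 2 to compound 1, but not the same: around the place in compound 3 the carbon is ortho to a methoxy group, meta to a large group and also meta to a methoxy group, whereas in compound 2 it is ortho to a methoxy group and meta to a large group only. Because the earlier change gave a number 20 percentage points lower from compound 2 to compound 1 (beyond the scatter), the same kind of change is expected to lower the number from compound 3 as well, though with the different surroundings and a different core the size is uncertain; the expected step is a number 13 percentage points lower from compound 3 to compound 4 (beyond the scatter). The estimate for compound 4 in this assay is 57%, expected to fall between 38% and 78%.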

Compound 4, a percentage reported as activity, at one concentration (the size of the read-out at that concentration, not a potency): 27%
The estimate for compound 4 lay 30 percentage points above the measured number; measured number outside the range, below it.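

In this assay the replacement of a methoxy group by hydrogen again went with a lower number and so a stronger effect, a number 43 percentage points lower from compound 3 to compound 4 (beyond the scatter), which means the direction of the change held on both cores. The size of the step did not carry over from one core to the other: the same change on two cores in this assay, a number 20 percentage points lower (beyond the scatter) from compound 2 to compound 1 and a number 43 percentage points lower (beyond the scatter) from compound 3 to compound 4, 23 percentage points apart, beyond the scatter of two such steps. These two pairs show only that the direction was shared and that a step measured on one core did not give the size of the step on the other; they do not show why the size differs, and they cannot separate the core from the surroundings of the place, since in compound 3 the carbon is also meta to a methoxy group, which is not so in compound 2.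

The compounds shown leave open how a hydroxy group, an ethoxy group or a fluorine atom at this place would compare with methoxy and hydrogen on either core. They also leave open whether the same direction would appear on a third core, or at concentrations other than the single one used here.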